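This account rests on a few compounds, and the source may have more. Where it says the series, first, only, none or still open, it means among the compounds named here.

Three compounds in the series have numbers in an in vitro functional assay on cells for agonist activity at Bombesin receptor subtype-3 (Mus musculus), read by luminescence and calcium flux; a higher number here means that more compound is needed for the effect, a lower number that less compound is needed. Compound 1 `CCCCc1cnc(CCCc2ccc(-c3ccccc3C(=O)O)cc2)[nH]1` gives 382 nM in this assay, and compound 3 `CCCCc1cnc(C(CC)Cc2ccc(-c3ccccc3C(=O)O)cc2)[nH]1` gives 340 nM. Compound 2 `O=C(O)c1ccccc1-c1ccc(CCc2ncc(Cc3ccccc3Cl)[nH]2)cc1` gives 22 nM, the lowest of the three; compound 3 stands nearest to it, with a gap beyond the scatter, and compound 1 stands furthest, also beyond the scatter. Within the data shown here, no two of these three differ in a single place, so no step between measured compounds is at hand to calibrate the change described next.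

Compound 4 `N#Cc1ccccc1Cc1cnc(CCc2ccc(-c3ccccc3C(=O)O)cc2)[nH]1` is the one to be measured next in this assay. It differs from compound 2 in one place: cyano in place of chloro on an aromatic carbon In the terms of the change, 2-chlorobenzyl becomes 2-cyanobenzyl, the new group sitting ortho to a large group. Without a measured pair of this kind, the expected step is a 2.3-fold higher number from compound 2 to compound 4 (0.36 log units; beyond the scatter), small, if anything toward a higher number, and possibly within the scatter. Compound 4 is expected to give about 50 nM in this assay, estimated within a range from 15 nM to 170 nM.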

Compound 4, half-maximal effective concentration: 642 nM
The estimate for compound 4 lay 13-fold (1.11 log units) below the measured number; the measured number lies above the stated range.
By their numbers in this assay, from the lowest: compound 2; then compounds 3, 1 and 4 (each within the scatter of the next).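

Going from 2-chlorobenzyl to 2-cyanobenzyl brings a 29-fold higher number from compound 2 to compound 4 (1.47 log units; beyond the scatter) in this assay and gives the series its first step that can be read at one position. Among these compounds, this position, on an aromatic carbon ortho to a large group, is therefore sensitive to the exchange of one substituent for another, which the earlier compounds could not show because no two of them differ in one place. The change is small in its counts, with chloro of 1 heavy atom leaving and cyano of 2 heavy atoms and 1 hydrogen-bond acceptor entering, and no measurement at hand accounts for the size of the step.

The unsubstituted benzyl, or a fluoro, methyl or methoxy group at this position, would show how much of the step belongs to the loss of chloro and how much to the arrival of cyano. From the compounds shown here alone, whether the same exchange carries a step of like size on another core remains open.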